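Benzyl substituent swap, compound 2 to compound 4

The source may report more compounds than this note shows. Statements on the series, on what has been measured and on what is new or still open speak of the compounds shown alone.

Three compounds in this series carry numbers in a functional assay on cells for positive allosteric modulation of G-protein coupled receptor 68 (Homo sapiens), read by a luciferase reporter and cAMP accumulation, with a stated time of 30 min, at pH 6.8 and pH 8.3, in the presence of a further agent that is not named here; a lower number here means a less potent compound, a higher number a more potent compound, by a factor of ten per unit of this negative logarithm. Compound 2 `Nc1nc(NCc2ccc(C(F)(F)F)cc2)nc(-c2ccccc2CO)n1` gives 5.03, the highest of the three. Compound 3 `Cc1cccc(CNc2nc(N)nc(-c3ccccc3CO)n2)c1` gives 4.4, below compound 2 by more than the scatter, and compound 1 `NCc1ccccc1-c1nc(N)nc(NCc2ccccc2)n1` gives 3.86, further below compound 2 and again beyond the scatter. Compound 4 `CC(C)Oc1ccc(CNc2nc(N)nc(-c3ccccc3CO)n2)cc1` is not yet measured. It differs from compound 2 in one place, (isopropoxy in place of trifluoromethyl on an aromatic carbon), isopropoxy in place of trifluoromethyl on an aromatic carbon, para to a large group. Among the compounds with values here, no measured pair shows this change, so the size of the step is uncertain. Since compound 2 gives 5.03 and the other benzyl substituents tried sit lower than it, a modest drop or no step beyond the scatter is expected. Compound 4 is estimated at 4.8, with a range from 4.2 to 5.4. The expected step of a number 0.23 log units lower from compound 2 to compound 4 (within the scatter) is small.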

Compound 4, negative logarithm of the antagonist equilibrium constant: 4.99
Compound 4: middle estimate off by 0.19 log units, on the low side; measured number inside the range.
By their numbers in this assay, from the lowest: compound 1; then compound 3; then compounds 4 and 2 (each within the scatter of the next).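

The swap to isopropoxy in place of trifluoromethyl gives a number 0.04 log units lower from compound 2 to compound 4 (within the scatter) in this assay. Within the data shown here, this position, para to a large group, therefore holds its number across two groups with different atoms and a different hydrogen-bond acceptor count, which the earlier compounds could not show. No measurement here accounts for this result.

Still open, going by these compounds, is whether an amine, a carboxylic acid or a longer alkoxy chain at this position would read the same. A single pair also leaves open whether this equivalence extends to other substituents.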